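A few compounds are considered here, and "the series" means these few. Any claim that something is new, unique, unknown or untested is made for them only; others in the source may bear on it.

The study begins with two close relatives, compound 1 `CC(C)(C)OC(=O)N1CCC[C@H]1C(=O)N1CCC(NS(=O)(=O)c2cc(S(=O)(=O)c3ccccc3)ccc2C(F)(F)F)CC1` and compound 2 `CC(C)(C)C(=O)N1CCC[C@H]1C(=O)N1CCC(NS(=O)(=O)c2cc(S(=O)(=O)c3ccccc3)ccc2C(F)(F)F)CC1`, both measured in a physicochemical assay for solubility; on this read-out lower numbers stand for lower solubility and higher numbers for higher solubility. There compound 1 gives 25000 nM and compound 2 gives 50000 nM. Going by the values given here, these are the only two numbers so far, and they lie within the scatter of each other, so compound 2 cannot be told apart from compound 1. Compound 3 `CC(C)(C)CC(=O)N1CCC[C@H]1C(=O)N1CCC(NS(=O)(=O)c2cc(S(=O)(=O)c3ccccc3)ccc2C(F)(F)F)CC1` keeps the rest of compound 2 and alters one group: neopentyl in place of tert-butyl on a carbonyl carbon, (neopentyl in place of tert-butyl on a carbonyl carbon). Among the compounds with values here, one measured step bears on this, a swap at the same place, a 2.0-fold higher number from compound 1 to compound 2 (0.30 log units; within the scatter). On these data alone, that step stayed within the scatter, so no step beyond the scatter is expected here, and the direction stays open. The expected step is a 1.4-fold lower number from compound 2 to compound 3 (0.15 log units; within the scatter). In this assay the estimate for compound 3 is 35000 nM, with a range of 12000 nM to 80000 nM.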

Compound 3, solubility: 25000 nM
For compound 3 the middle estimate is 1.4-fold (0.15 log units) above the measured one; the measured number falls inside the stated range.
By their numbers in this assay, from the lowest: compounds 1, 3 and 2 (each within the scatter of the next).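

In this assay the neopentyl group gives a 2.0-fold lower number from compound 2 to compound 3 (0.30 log units; within the scatter) and no change at the digits printed from compound 1 to compound 3 (within the scatter) on the same carbonyl carbon. Tert-butoxy, tert-butyl and neopentyl have now all been tested at this place, and none of the three can be told apart from the others, so these swaps, including the step from 4 to 5 heavy atoms in the group, show no effect beyond the scatter. Nothing available here offers an explanation for this flat result.

On these data alone, whether the same holds for an amine, a carboxylic acid or a longer chain on this carbonyl carbon remains open. Also open, as far as these compounds go, is whether changes elsewhere in the shared core would move the read-out further than these swaps did.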